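The source may report more compounds than this note shows. Statements on the series, on what has been measured and on what is new or still open speak of the compounds shown alone.

In a functional assay on HCT-116 cells (Homo sapiens) for inhibition, read by CCK-8 assay, with a stated time of 48 h (on this read-out higher numbers stand for weaker inhibition and lower numbers for stronger inhibition), compound 1 `COc1cc(-c2ccnc3cc(-c4ccc5cc[nH]c5c4)nn23)cc(OC)c1OC` gives 187 nM and compound 2 `COc1cc(-c2ccnc3cc(-c4ccc5cnn(C)c5c4)nn23)cc(OC)c1OC` gives 2440 nM, so compound 2 holds the higher of the two numbers and the weaker inhibition. The next compound, compound 3 `COc1cc(-c2ccnc3cc(-c4ccc(C(C)(C)C)cc4)nn23)cc(OC)c1OC`, keeps the shared core and differs from compound 2 in one group: 4-(tert-butyl)phenyl in place of 1-methyl-1H-indazol-6-yl on an aromatic carbon. Thus 4-(tert-butyl)phenyl stands in place of 1-methyl-1H-indazol-6-yl, and the entering group has no hydrogen-bond acceptors where the leaving group has them. Among the measured compounds shown here, only one measured step bears on this place, a 13-fold higher number from compound 1 to compound 2 (1.12 log units; beyond the scatter), a large step that came with 1-methyl-1H-indazol-6-yl replacing 1H-indol-6-yl. For the measured compounds named here, it shows that a change here can move the number far, but no measured compound carries 4-(tert-butyl)phenyl. With compound 1 at 187 nM and compound 2 at 2440 nM, a moderate move towards a lower number is expected, with much uncertainty. The estimated step in this assay is a 1.9-fold lower number from compound 2 to compound 3 (0.27 log units; within the scatter). Compound 3 is expected at 1300 nM, with an estimated range of 300 nM to 6000 nM.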

Compound 3, half-maximal inhibitory concentration: > 10000 nM
Compound 3 was reported as a limit; the forecaster's own chance of this, stated with the estimate: 10%; middle value at least 7.6-fold (0.88 log units) away from the limit.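

Compound 3 stands at a limit of the assay and not at a number: the limit of > 10000 nM in this assay, at which 1 of the 3 values shown sits. In this assay, replacing either fused group with 4-(tert-butyl)phenyl still gives readable steps, an at least 4.0-fold higher number from compound 2 to compound 3 (0.61 log units; beyond the scatter) and an at least 53-fold higher number from compound 1 to compound 3 (1.72 log units; beyond the scatter), so the loss at this position is larger than the earlier step alone had shown. The earlier compounds shown here compared only 1H-indol-6-yl with 1-methyl-1H-indazol-6-yl, whereas compound 3 shows that a group with the same heavy-atom count as 1-methyl-1H-indazol-6-yl, but with one six-membered aromatic ring of carbon only and no hydrogen-bond acceptors, gives much weaker inhibition, so heavy-atom count alone does not set the number here.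

The compounds shown do not separate the loss of the five-membered aromatic ring and its nitrogen atoms from the arrival of the tert-butyl group, as the two changes occur together in compound 3, and how far its true value lies past the limit cannot be read. Going by these compounds, it also stays open whether an unsubstituted phenyl, or a phenyl carrying an amine or a methoxy group in place of tert-butyl, would bring the number back towards that of compound 1.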